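A few compounds are considered here, and "the series" means these few. Any claim that something is new, unique, unknown or untested is made for them only; others in the source may bear on it.

Working notes on the aryl-triazole series. Compound 2 `CC(C)c1ccc(-n2cc(COc3cccc(NC(=O)Nc4ccc(Cl)c(C(F)(F)F)c4)c3)nn2)cc1` gives 2470 nM in a functional assay on HepG2 cells (Homo sapiens) for inhibition, read by MTT assay, with a stated time of 72 h; on this read-out lower numbers stand for stronger inhibition and higher numbers for weaker inhibition; this is the lowest number of the three measured, but neither neighbour is separated from it beyond the scatter. Compound 1 `CC(C)c1cccc(-n2cc(COc3cccc(NC(=O)Nc4ccc(Cl)c(C(F)(F)F)c4)c3)nn2)c1` gives 3250 nM in this assay, and compound 3 `O=C(Nc1cccc(OCc2cn(-c3ccc(Br)cc3)nn2)c1)Nc1ccc(Cl)c(C(F)(F)F)c1` gives 2730 nM. The three steps among them all change the group on the aromatic nitrogen: a 1.3-fold lower number from compound 1 to compound 2 (0.12 log units; within the scatter), a 1.2-fold lower number from compound 1 to compound 3 (0.08 log units; within the scatter), and a 1.1-fold higher number from compound 2 to compound 3 (0.04 log units; within the scatter). None of these steps leaves the scatter.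

Compound 4 `O=C(Nc1cccc(OCc2cn(-c3ccccc3C(F)(F)F)nn2)c1)Nc1ccc(Cl)c(C(F)(F)F)c1` is the next member, differing from compound 2 by 2-(trifluoromethyl)phenyl in place of 4-isopropylphenyl on an aromatic nitrogen. All three measured steps bear on this change, since each swaps the aryl group on the same aromatic nitrogen, and each was too small to read as a real shift. Among the measured compounds shown here, a 2-(trifluoromethyl)phenyl group has not been measured in this position, so the data give no direct step for it; what they show is that 3-isopropylphenyl, 4-isopropylphenyl and 4-bromophenyl all land in the same band in this assay. No step beyond the scatter is therefore expected in either direction, and compound 4 is estimated at 2800 nM, with a range of 1200 nM to 6500 nM, which corresponds to an expected step of a 1.1-fold higher number from compound 2 to compound 4 (0.05 log units; within the scatter).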

Compound 4, half-maximal inhibitory concentration: 2320 nM
Estimate against measurement, compound 4: 1.2-fold (0.08 log units) above, within the range that was stated.
By their numbers in this assay, from the lowest: compounds 4, 2, 3 and 1 (each within the scatter of the next).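

The 2-(trifluoromethyl)phenyl group on the aromatic nitrogen stays in the same band in this assay as the three earlier aryl groups, with a 1.1-fold lower number from compound 2 to compound 4 (0.03 log units; within the scatter) and a 1.2-fold lower number from compound 3 to compound 4 (0.07 log units; within the scatter) and also a 1.4-fold lower number from compound 1 to compound 4 (0.15 log units; within the scatter) as its steps. The band seen so far for 3-isopropylphenyl, 4-isopropylphenyl and 4-bromophenyl therefore extends to a fourth aryl group, one that carries fluorine and has its substituent at a different place in its name, so across these four compounds neither the identity of the substituent nor its numbered place on the phenyl ring separates the values beyond the scatter. Nothing at hand bears on why these four values stay together.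

On these data alone, all four compounds keep the same shared core and an uncharged aryl group carrying carbon, bromine or fluorine substituents, so it remains open whether a phenyl ring bearing a carboxylic acid or an amine, or a longer chain in place of the aryl group, would move the number beyond the scatter. As far as these compounds go, how the number responds to a change elsewhere in the core also stays open, as every step here sits on the one aromatic nitrogen.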